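From Amide to Urea: Two Limits and an Expectation

A few compounds are considered here, and "the series" means these few. Any claim that something is new, unique, unknown or untested is made for them only; others in the source may bear on it.

Compound 1 `O=C(Nc1cccc(-n2cc(-c3ccncc3)c(-c3ccc(Cl)c(O)c3)n2)c1)Nc1cccc(C(F)(F)F)c1` — > 32500 nM
Compound 2 `COc1cc(-c2nn(-c3cccc(NC(=O)c4cccc(C(F)(F)F)c4)c3)cc2-c2ccncc2)ccc1Cl` — > 50000 nM

In a functional assay on NCI-H226 cells (Homo sapiens) for inhibition, read by sulforhodamine B assay, with a stated time of 48 h (a higher number here means that more compound is tolerated, a lower number that less compound is tolerated), compound 1 gives > 32500 nM, which is a limit of the assay and not a number. Compound 2 gives > 50000 nM in this assay, again a limit rather than a number. Among the measured compounds shown here, compound 2 thus stands with only a limit to its name, and the single further value shown is a limit as well: the limit of > 32500 nM in this assay, at which 1 of the 2 values shown sits, and the limit of > 50000 nM in this assay, at which 1 of the 2 values shown sits, are all that this assay offers here, and no measured step between two compounds exists to lean on.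

Compound 3 `COc1cc(-c2nn(-c3cccc(NC(=O)Nc4ccc(Cl)c(Cl)c4)c3)cc2-c2ccncc2)ccc1Cl` differs from compound 2 by (3,4-dichlorophenyl)amino in place of 3-(trifluoromethyl)phenyl on a carbonyl carbon. With both shown values sitting at limits, the step from compound 2 to compound 3 is expected to be none beyond the scatter, which is what a number no higher from compound 2 to compound 3 (the limit leaves the size open) expresses. For compound 3 in this assay the estimate is 50000 nM, expected to fall between 15000 nM and 160000 nM, most probably reported again as a limit.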

Compound 3, concentration lethal to 50% of the cells: > 50000 nM
Compound 3: no number, only a limit; the forecaster's own chance of this, stated with the estimate: 75%; the middle value lies on the limit itself.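

Compound 2 and compound 3 each give only a limit in this assay, and no step can be read between them. The compounds shown leave open where the actual value of each lies, and whether this exchange on the carbonyl carbon changes it at all.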